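The compounds below may be only part of what the source reports. "The series", "measured", "known", "first", "only" and "open" are said of these compounds alone.

Compound 1 `CC(CO)Nc1nc(N)nc2c1ncn2[C@H]1C[C@H](N=[N+]=[N-])[C@@H](CO)O1`: > 100000 nM (a limit of the assay)
Compound 2 `[N-]=[N+]=N[C@H]1C[C@H](n2cnc3c(Cl)nc(F)nc32)O[C@@H]1CO`: 7200 nM

Among the compounds with values here, in an ADME assay on PBMC cells (Homo sapiens) for cytotoxicity, with a stated time of 5 days (a higher number here means a weaker inhibitor, a lower number a stronger inhibitor), compound 2 gives 7200 nM as the only true number so far. Compound 3 `[N-]=[N+]=N[C@H]1C[C@H](n2cnc3c(N)nc(F)nc32)O[C@@H]1CO` has amino in place of chloro on an aromatic carbon. Within the data shown here, no measured step covers this change. Compound 1 lacks the chloro group and gives > 100000 nM as a limit of the assay, so a shift towards weaker inhibition, beyond the scatter, is expected. The estimated shift (a 4.2-fold higher number from compound 2 to compound 3 (0.62 log units; beyond the scatter)) remains tentative. For compound 3 the expected value is 30000 nM with 5000 nM to 100000 nM as the estimated range.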

Compound 3, half-maximal inhibitory concentration: 30100 nM
Beside the measured number, compound 3's estimate is 1.0-fold (0.00 log units) below it; the measured number falls inside the stated range.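

Amino in place of chloro on this aromatic carbon, next to the ring nitrogen and meta to a fluoro group, gives a 4.2-fold higher number from compound 2 to compound 3 (0.62 log units; beyond the scatter) in this assay. Within the data shown here, this is the first readable single-place change, and it shows that the read-out responds to the group at this position. Compound 3 still gives a true number rather than a limit, so the read-out keeps room at its upper end: the limit of > 100000 nM in this assay, at which 1 of the 3 values shown sits.

From the compounds shown here alone, how a methoxy group or a thiol at this carbon would read stays open. So does whether the step holds with another group in place of the fluoro group.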